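This account rests on a few compounds, and the source may have more. Where it says the series, first, only, none or still open, it means among the compounds named here.

Measured so far:
compound 1, `C[C@@H]1CN(C(=O)c2nc(Nc3cc(C4CC4)[nH]n3)c3cc(Cl)ccc3n2)CCN1C(=O)OC(C)(C)C`, 22.7%
compound 2, `CCCCCOC(=O)N1CCN(C(=O)c2nc(Nc3cc(C4CC4)[nH]n3)c3cc(Cl)ccc3n2)C[C@H]1C`, 12.6%
compound 3, `C[C@@H]1CN(C(=O)c2nc(Nc3cc(C4CC4)[nH]n3)c3cc(Cl)ccc3n2)CCN1C(=O)OCC(Cl)(Cl)Cl`, 63%

All three share one core and differ only in the group on an oxygen next to a carbonyl group, read in an assay for inhibition of serine/threonine-protein kinase PAK 4 (Homo sapiens), read by FRET and Z'-LYTE, with a stated time of 60 min, tested at 5 uM, in the presence of a further agent that is not named here; on this read-out higher numbers stand for a stronger effect at the one concentration tested and lower numbers for a weaker effect. Compound 2 stands lowest of the three: the step of a number 10.1 percentage points lower from compound 1 to compound 2 (beyond the scatter) is modest, while a number 50.4 percentage points higher from compound 2 to compound 3 (beyond the scatter) is large. Compound 4, `CC(C)COC(=O)N1CCN(C(=O)c2nc(Nc3cc(C4CC4)[nH]n3)c3cc(Cl)ccc3n2)C[C@H]1C`, is not yet measured; it differs from compound 2 by isopropyl in place of butyl on a saturated chain carbon bound to an oxygen next to a carbonyl group. Among the compounds with values here, two steps bear on this: a number 10.1 percentage points lower from compound 1 to compound 2 (beyond the scatter), and a number 50.4 percentage points higher from compound 2 to compound 3 (beyond the scatter), where trichloromethyl entered. The entering isopropyl carries no chlorine, so a change of the size seen between compound 1 and compound 2, pointing back upward, is expected: a number 6.4 percentage points higher from compound 2 to compound 4 (within the scatter). Compound 4 is estimated at 19%, likely between 6% and 34%.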

Compound 4, a percentage reported as inhibition, at one concentration (the size of the read-out at that concentration, not a potency): 30.7%
Estimate against measurement, compound 4: 11.7 percentage points below; the range from low to high includes it.
By their numbers in this assay, from the lowest: compound 2; then compounds 1 and 4 (each within the scatter of the next); then compound 3.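

Replacing the pentyl group with the branched isobutyl group gives a number 18.1 percentage points higher from compound 2 to compound 4 (beyond the scatter), so a chlorine-free group can also shift this read-out beyond the scatter. The two branched groups stay close, with a number 8 percentage points higher from compound 1 to compound 4 (within the scatter), while compound 3 keeps its chlorine-bearing group apart, with a number 32.3 percentage points lower from compound 3 to compound 4 (beyond the scatter). Pentyl is a single example, so these compounds do not establish that branching itself matters.

No supporting data explain these differences. From the compounds shown here alone, it remains open whether an ethyl chain, or a 2,2,2-trifluoroethyl group with fluorine in place of chlorine, would read nearer compound 4 or compound 3.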